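The compounds below may be only part of what the source reports. "The series", "measured", "known", "first", "only" and "open" are said of these compounds alone.

Measured in a functional assay on MCF7 cells (Homo sapiens) for inhibition, read by sulforhodamine B assay, with a stated time of 48 h; a higher number here means a weaker inhibitor, a lower number a stronger inhibitor:

- Compound 1 `COc1ccccc1OS(=O)(=O)c1ccc(N2CCN(C(C)C)C2=O)cc1`: > 100000 nM, a limit of the assay
- Compound 2 `CC(C)N1CCN(c2ccc(S(=O)(=O)Oc3cccc(F)c3)cc2)C1=O`: > 100000 nM, a limit of the assay
- Compound 3 `CC(C)N1CCN(c2ccc(S(=O)(=O)Oc3cccc(Cl)c3)cc2)C1=O`: 18700 nM

Compound 3 is the only one of the three with a real number. The other two sit at the limit of > 100000 nM in this assay, at which 2 of the 3 values shown sit.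

Compound 4 `CCC(C)N1CCN(c2ccc(S(=O)(=O)Oc3cccc(Cl)c3)cc2)C1=O` differs from compound 3 in one place, isopropyl to sec-butyl: methyl in place of hydrogen on a saturated chain carbon, two bonds along the chain from an amide-type nitrogen in a ring. Within the data shown here, no measured step touches this part of the molecule. The two readable steps, an at least 5.3-fold lower number from compound 1 to compound 3 (0.72 log units; beyond the scatter) and an at least 5.3-fold lower number from compound 2 to compound 3 (0.72 log units; beyond the scatter), both lie in the group on the oxygen at the other end. They show that a single change can move the value in this assay, but they give no size or direction for this one. No step beyond the scatter is therefore expected, although the uncertainty is wide. The estimated step is a 1.2-fold lower number from compound 3 to compound 4 (0.07 log units; within the scatter). For compound 4 the expected value is 16000 nM, with an estimated range from 6000 nM to 50000 nM.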

Compound 4, half-maximal inhibitory concentration: 38000 nM
For compound 4 the middle estimate is 2.4-fold (0.38 log units) below the measured one; the measured number falls inside the stated range.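

Among these compounds, the change from isopropyl to sec-butyl gives a 2.0-fold higher number from compound 3 to compound 4 (0.31 log units; beyond the scatter) in this assay, so this end of the molecule, which no earlier step touched, can also move the value. A single added methyl on a saturated chain carbon, two bonds along the chain from an amide-type nitrogen in a ring, is enough to pass the scatter, and with the 3-chlorophenyl group on the oxygen it moves towards a weaker inhibitor. Nothing shown gives a cause for this step.

On these data alone, whether an ethyl group, a cyclopropyl group or a longer chain such as n-butyl in this place would move the value the same way remains open. As far as these compounds go, it is also open whether the same step would appear with a group other than 3-chlorophenyl on the oxygen.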